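A few compounds are considered here, and "the series" means these few. Any claim that something is new, unique, unknown or untested is made for them only; others in the source may bear on it.

Three compounds share one core. In an ADME assay on S9 fraction from liver (Mus musculus, strain ICR/CD-1) for metabolic stability, read by LC-MS, using NADPH, with a stated time of 5 min, tested at 2 uM (on this read-out higher numbers stand for a longer-lived compound and lower numbers for a shorter-lived compound), compound 1 `CC1CCN(C2CCN(S(=O)(=O)c3cccc(Br)c3)CC2)CC1` gives 0.217 h, compound 2 `CC1CCN(C2CCN(S(=O)(=O)c3cccc(-c4ccc(F)cc4)c3)CC2)CC1` gives 1.28 h, and compound 3 `Cc1ccc(-c2cccc(S(=O)(=O)N3CCC(N4CCC(C)CC4)CC3)c2)cc1` gives 1.92 h. Compound 3 holds the highest number shown, although its gap to compound 2 is within the scatter; only its gap to compound 1 lies beyond it. Putting 4-fluorophenyl or 4-methylphenyl in place of bromo gave a 5.9-fold higher number from compound 1 to compound 2 (0.77 log units; beyond the scatter) and an 8.8-fold higher number from compound 1 to compound 3 (0.95 log units; beyond the scatter), whereas a 1.5-fold higher number from compound 2 to compound 3 (0.18 log units; within the scatter). Compound 4 `CC1CCN(C2CCN(S(=O)(=O)c3cccc(-c4ccc5ccccc5c4)c3)CC2)CC1` carries naphthalen-2-yl in place of 4-methylphenyl on an aromatic carbon. Going by the values given here, no measured step exchanges one aromatic group for a larger one. Compound 4 is therefore expected to move only a 1.2-fold lower number from compound 3 to compound 4 (0.08 log units; within the scatter), within the scatter. In this assay compound 4 is estimated at 1.6 h, from 0.7 h to 3.5 h.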

Compound 4, half-life: 3.4 h
The estimate for compound 4 lay 2.1-fold (0.33 log units) below the measured number; measured number inside the range.
By their numbers in this assay, from the lowest: compound 1; then compounds 2, 3 and 4 (each within the scatter of the next, the first and the last beyond it).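

On this aromatic carbon, meta to a large group, the exchange to 2 six-membered aromatic rings of carbon only can now be read in this assay: naphthalen-2-yl in place of 4-methylphenyl gives a 1.8-fold higher number from compound 3 to compound 4 (0.25 log units; within the scatter) and in place of 4-fluorophenyl gives a 2.7-fold higher number from compound 2 to compound 4 (0.42 log units; beyond the scatter). In place of bromo it gives a 16-fold higher number from compound 1 to compound 4 (1.20 log units; beyond the scatter), the only step shown that is printed as large. Nothing given here accounts for these steps. The compounds shown leave open how the half-life would respond to an amine or a carboxylic acid on the aromatic group at this position, since every aromatic group shown is of carbon only and carries no hydrogen-bond donor or acceptor.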